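From Methylsulfonyl to Methylsulfanyl in a Growth Inhibition Test

A few compounds are considered here, and "the series" means these few. Any claim that something is new, unique, unknown or untested is made for them only; others in the source may bear on it.

In a functional assay on DU-145 cells (Homo sapiens) for inhibition, read by trypan blue exclusion, with a stated time of 96 h (on this read-out lower numbers stand for stronger inhibition of growth and higher numbers for weaker inhibition of growth), compound 1 (`Cc1ccc(CS(=O)(=O)/C(=C/c2ccc(S(C)(=O)=O)cc2)C(=O)c2ccc(Br)cc2)cc1`) gives 10000 nM. That is level with compound 2 (`O=C(/C(=C\c1ccc(O)c([N+](=O)[O-])c1)SCc1ccc(Br)cc1)c1ccc(Cl)cc1Cl`), which gives 10000 nM. These two compounds differ in more than one place, so no measured single change is available as a guide. Compound 3 (`CSc1ccc(/C=C(\C(=O)c2ccc(Br)cc2)S(=O)(=O)Cc2ccc(C)cc2)cc1`) has methylsulfanyl in place of methylsulfonyl on an aromatic carbon, para to a large group (methylsulfanyl in place of methylsulfonyl on an aromatic carbon). A moderate gain in growth inhibition is expected, with a lower number and an estimated step of a 2.5-fold lower number from compound 1 to compound 3 (0.40 log units; beyond the scatter). The estimated value for compound 3 is 4000 nM, within a range from 500 nM to 15000 nM.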

Compound 3, concentration for 50% growth inhibition: 10000 nM
The estimate for compound 3 lay 2.5-fold (0.40 log units) below the measured number; the range from low to high includes it.
By their numbers in this assay, from the lowest: compounds 1, 2 and 3 (each within the scatter of the next).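

Among these compounds, replacing methylsulfonyl with methylsulfanyl on this aromatic carbon, para to a large group, gives the first single change that can be read in this assay, and the result is no change at the digits printed from compound 1 to compound 3 (within the scatter) for growth inhibition. At this position on the core of compound 1, the smaller group and the larger one therefore cannot be told apart by this read-out. No other measurement here bears on this result. Going by these compounds, whether an amine or a carboxylic acid at this position would give a different number remains open. So does whether the same change would give the same result on a different core.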